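Replacing Acetamido with 2-Methylpiperazinyl on a Urea Core

The compounds below may be only part of what the source reports. "The series", "measured", "known", "first", "only" and "open" are said of these compounds alone.

This set of three measured compounds shares a diaryl urea joined through an ether to a six-membered aromatic ring with two nitrogens, and differs only in the group carried on that ring. Compound 1 `COc1ccc(CNc2cc(Oc3ccc(NC(=O)Nc4ccc(C)c(C(F)(F)F)c4)cc3)ncn2)cc1` gives 1000 nM in a functional assay on BaF3 cells (Mus musculus) for inhibition, read by CCK-8 assay, with a stated time of 72 h; on this read-out lower numbers stand for stronger inhibition of growth and higher numbers for weaker inhibition of growth. Compound 2 `Cc1ccc(NC(=O)Nc2ccc(Oc3cc(/N=C/N(C)C)ncn3)cc2)cc1C(F)(F)F` gives 6610 nM in this assay, and compound 3 `CC(=O)Nc1cc(Oc2ccc(NC(=O)Nc3ccc(C)c(C(F)(F)F)c3)cc2)ncn1` gives 3230 nM in this assay. Compound 3 therefore stands second highest of the three numbers, with a 2.0-fold lower number from compound 2 to compound 3 (0.31 log units; beyond the scatter) and a 3.2-fold higher number from compound 1 to compound 3 (0.51 log units; beyond the scatter) placing it between the other two.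

Compound 4 `Cc1ccc(NC(=O)Nc2ccc(Oc3cc(N4CCNC[C@@H]4C)ncn3)cc2)cc1C(F)(F)F` has not yet been measured. Its difference from compound 3 is 2-methylpiperazin-1-yl in place of acetamido on an aromatic carbon. For the measured compounds named here, no measured step swaps in a ring-containing amine at this position, so the two steps that touch the same aromatic carbon, a 3.2-fold higher number from compound 1 to compound 3 (0.51 log units; beyond the scatter) and a 2.0-fold lower number from compound 2 to compound 3 (0.31 log units; beyond the scatter), are the only guide, and both are modest in size. On that basis a modest step in either direction is plausible, and the estimate for compound 4 is expected to be a 2.7-fold lower number from compound 3 to compound 4 (0.43 log units; beyond the scatter), giving an expected value of 1200 nM with a range from 200 nM to 6000 nM.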

Compound 4, concentration for 50% growth inhibition: 8120 nM
Estimate against measurement, compound 4: 6.8-fold (0.83 log units) below; measured number outside the range, above it.
By their numbers in this assay, from the lowest: compound 1; then compound 3; then compounds 2 and 4 (each within the scatter of the next).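

In this assay, putting 2-methylpiperazin-1-yl on this aromatic carbon in place of acetamido gives a 2.5-fold higher number from compound 3 to compound 4 (0.40 log units; beyond the scatter), so this first ring-containing amine at the position does not lower the number. Set against the (4-methoxybenzyl)amino group, the same ring gives an 8.1-fold higher number from compound 1 to compound 4 (0.91 log units; beyond the scatter), the widest gap among these compounds, whereas the comparison with the open-chain group of compound 2 gives a 1.2-fold higher number from compound 2 to compound 4 (0.09 log units; within the scatter), so those two quite different groups cannot be told apart here. Nothing available explains why the piperazine ring behaves this way at this position.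

A plain piperazin-1-yl group, or the mirror-image form of the 2-methyl ring, would show whether the methyl group and its defined stereocentre matter to the result. A plain benzylamino group would likewise separate the part played by the methoxy group from that of the benzyl ring in compound 1, which still has the lowest number.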